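Swapping an Imidazole Arm for a Triazolylmethyl Arm

The source may hold more compounds than are shown below. What is called first, only, known or untested is meant among the compounds shown, and "the series" means these compounds.

Compound 1 `Cn1cc(C2=C(c3nn(CCn4ccnc4)c4ncccc34)C(=O)NC2=O)c2ccccc21` was tested in a functional assay on A549 cells (Homo sapiens) for antiproliferative activity, read by MTT assay, with a stated time of 48 h; on this read-out lower numbers stand for stronger inhibition and higher numbers for weaker inhibition. In this assay compound 1 reaches only the limit > 100000 nM, which is a limit of the measurement and not a number. A second member of the same series, compound 2 `Cn1cc(C2=C(c3nn(CCCN4CCCCC4)c4ncccc34)C(=O)N(c3ccc(Cl)cc3)C2=O)c2ccccc21`, gives 28700 nM in this assay; no single-step comparison connects it to compound 1, so the two values simply stand side by side. Where compound 1 stands is therefore known only as a limit, as the limit of > 100000 nM in this assay, at which 1 of the 2 values shown sits, shows. Compound 3 `Cn1cc(C2=C(c3nn(CCCn4cncn4)c4ncccc34)C(=O)NC2=O)c2ccccc21` differs from compound 1 in one place: (1H-1,2,4-triazol-1-yl)methyl in place of 1H-imidazol-1-yl on a saturated chain carbon, two bonds along the chain from an aromatic nitrogen. Going by the values given here, no measured step of this kind exists among the compounds here, so the expectation rests on compound 1 alone. The step of a number no higher from compound 1 to compound 3 (the limit leaves the size open) is expected to stay within the usual scatter, in no clear direction. The estimate for compound 3 in this assay is 100000 nM, with a range from 30000 nM to 300000 nM.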

Compound 3, half-maximal inhibitory concentration: > 100000 nM
Compound 3 was reported as a limit (the forecaster's own chance of this, stated with the estimate: 60%); the middle value lies on the limit itself.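

No step can be read from compound 1 to compound 3, since both results are limits and not numbers: the limit of > 100000 nM in this assay, at which 2 of the 3 values shown sit.

The compounds shown leave open whether (1H-1,2,4-triazol-1-yl)methyl in place of 1H-imidazol-1-yl makes any difference in this assay.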